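Trifluoromethyl in Place of Fluoro: What to Expect

The source may hold more compounds than are shown below. What is called first, only, known or untested is meant among the compounds shown, and "the series" means these compounds.

Within the data shown here, compound 1 `Oc1cccc(-c2cc(-c3ccccc3F)cc(-c3cccc(O)c3)n2)c1` is, on the numbers so far, the weaker of two measured compounds, though only nominally so. In a functional assay on HeLa cells (Homo sapiens) for inhibition (on this read-out lower numbers stand for stronger inhibition and higher numbers for weaker inhibition), compound 1 gives 16000 nM. Among the measured compounds shown here, compound 2 `Oc1ccc(-c2cc(-c3ccccc3F)cc(-c3cccc(O)c3)n2)cc1` gives 14300 nM in this assay, and the one measured step, a 1.1-fold lower number from compound 1 to compound 2 (0.05 log units; within the scatter), concerns the hydroxyphenyl group and says nothing about the fluorinated ring.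

Compound 3 `Oc1cccc(-c2cc(-c3ccccc3C(F)(F)F)cc(-c3cccc(O)c3)n2)c1` differs from compound 1 by trifluoromethyl in place of fluoro on an aromatic carbon. For the measured compounds named here, no measured step touches this part of the molecule, so nothing in the data points to a direction. Going by the values given here, the one step that is known was flat, which at least shows that small changes on the outer rings have left the read-out unmoved. Compound 3 is therefore expected to give about 15000 nM, roughly between 5000 nM and 45000 nM, meaning an expected step of a 1.1-fold lower number from compound 1 to compound 3 (0.03 log units; within the scatter), within the scatter.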

Compound 3, half-maximal inhibitory concentration: 15200 nM
Compound 3: middle estimate off by 1.0-fold (0.01 log units), on the low side; the range from low to high includes it.
By their numbers in this assay, from the lowest: compounds 2, 3 and 1 (each within the scatter of the next).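

In this assay, trifluoromethyl in place of fluoro gives a 1.1-fold lower number from compound 1 to compound 3 (0.02 log units; within the scatter). Among these compounds, this is the first measured change on the fluorinated ring, and it shows that a group of 4 heavy atoms can replace one of 1 heavy atom on this aromatic carbon, ortho to a large group, with no change beyond the scatter. Nothing measured here explains why the number holds steady at this position.

Only fluoro and trifluoromethyl have been seen at this position, so an amine, a carboxylic acid or a longer chain such as propyl could still give a different result. From the compounds shown here alone, it also remains open whether trifluoromethyl would give the same result when paired with the 4-hydroxyphenyl group of compound 2.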